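The compounds below may be only part of what the source reports. "The series", "measured", "known", "first", "only" and "open" are said of these compounds alone.

Compound 1 `Cc1cccc(NC(=O)CN2CCC(c3ccccc3)CC2)c1`: 37%
Compound 2 `Cc1cccc(NC(=O)CN2CCC(c3ccc(O)cn3)CC2)c1`: 83%
Compound 3 `Cc1cccc(NC(=O)CN2CCC(c3ccccc3C#N)CC2)c1`: 71%

In a functional assay on HEK293 cells for agonist activity at D(4) dopamine receptor (Homo sapiens), read by FLIPR (on this read-out lower numbers stand for smaller maximal responses and higher numbers for larger maximal responses), compound 3 gives 71%, the second highest of the three numbers. Its nearest neighbour is compound 2, with a number 12 percentage points lower from compound 2 to compound 3 (beyond the scatter); its furthest is compound 1, with a number 34 percentage points higher from compound 1 to compound 3 (beyond the scatter).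

Compound 4 `Cc1cccc(NC(=O)CN2CCC(c3ccccc3F)CC2)c1` differs from compound 3 by fluoro in place of cyano on an aromatic carbon. Among the measured compounds shown here, only one measured step touches this position, a number 34 percentage points higher from compound 1 to compound 3 (beyond the scatter), which was large. Fluoro enters as a single heavy atom with no hydrogen-bond acceptor, so compound 4 is expected to fall between compound 1 and compound 3, giving an estimated step of a number 19 percentage points lower from compound 3 to compound 4 (beyond the scatter). Compound 4 is therefore expected to give about 52% in this assay, with a likely range from 32% to 72%.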

Compound 4, largest response reached (reported as efficacy), in percent of the reference or control that the assay uses: 57%
For compound 4 the middle estimate is 5 percentage points below the measured one, and the stated range covers the measured number.
By their numbers in this assay, from the lowest: compound 1; then compound 4; then compound 3; then compound 2.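

In this assay, fluoro alone gives a number 20 percentage points higher from compound 1 to compound 4 (beyond the scatter) and so accounts for part of the rise at this position, without the hydrogen-bond acceptor that cyano carries. Cyano still keeps an edge, since the change to fluoro gives a number 14 percentage points lower from compound 3 to compound 4 (beyond the scatter) on the same aromatic carbon. The 2-fluorophenyl group also falls short of 5-hydroxypyridin-2-yl, with a number 26 percentage points lower from compound 2 to compound 4 (beyond the scatter) at the saturated ring carbon. No available evidence explains these steps. As far as these compounds go, whether chloro, methoxy or an amine at this place would fit the same order remains open.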